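A few compounds are considered here, and "the series" means these few. Any claim that something is new, unique, unknown or untested is made for them only; others in the source may bear on it.

Measured so far in a functional assay on SK-MEL-5 cells (Homo sapiens) for cytotoxicity, read by sulforhodamine B assay, with a stated time of 48 h, tested at 0.1 uM; on this read-out higher numbers stand for a weaker effect at the one concentration tested and lower numbers for a stronger effect: compound 1 `COc1cc(-c2cc(/C=C/C(=O)c3ccc(N)cc3)[nH]n2)cc(OC)c1OC` gives 95%; compound 2 `COc1cc(-c2cc(/C=C/C(=O)c3ccc(Cl)c(Cl)c3)[nH]n2)cc(OC)c1OC` gives 97%; compound 3 `COc1ccc(C(=O)/C=C/c2cc(-c3cc(OC)c(OC)c(OC)c3)n[nH]2)cc1OC` gives 96%.

Compound 3 stands second highest of these three numbers, its nearest neighbour being compound 1 with a number 1 percentage points higher from compound 1 to compound 3 (within the scatter), and its furthest compound 2 with a number 1 percentage points lower from compound 2 to compound 3 (within the scatter). Compound 4 `COc1cc(C(=O)/C=C/c2cc(-c3cc(OC)c(OC)c(OC)c3)n[nH]2)cc(OC)c1OC` differs from compound 3 by methoxy in place of hydrogen on an aromatic carbon. Among the measured compounds shown here, the steps that bear on this all alter the group on the carbonyl carbon: a number 2 percentage points higher from compound 1 to compound 2 (within the scatter) and a number 1 percentage points higher from compound 1 to compound 3 (within the scatter). Each stayed within the scatter, so in this assay no step beyond the scatter is expected for no change at the digits printed from compound 3 to compound 4 (within the scatter). Compound 4 is therefore estimated at 96%, within 88% to 100%.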

Compound 4, a percentage reported as activity, at one concentration (the size of the read-out at that concentration, not a potency): 95%
Beside the measured number, compound 4's estimate is 1 percentage points above it; the measured number falls inside the stated range.
By their numbers in this assay, from the lowest: compounds 1, 4, 3 and 2 (each within the scatter of the next).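

Where the earlier steps swapped the whole group on the carbonyl carbon, this one adds only a methoxy on an aromatic carbon, ortho to a methoxy group, and in this assay it gives a number 1 percentage points lower from compound 3 to compound 4 (within the scatter). At this position and this one concentration, then, the ring carries the added methoxy without a step beyond the scatter. Nothing available accounts for this result. From the compounds shown here alone, whether an amine, a carboxylic acid or a longer chain in place of that methoxy would stay within the scatter remains open. So does whether a higher concentration would separate compound 3 and compound 4.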